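This account rests on a few compounds, and the source may have more. Where it says the series, first, only, none or still open, it means among the compounds named here.

Measured in an assay (Cricetulus griseus) for inhibition of Monoamine oxidase (Homo sapiens); a lower number here means a stronger inhibitor, a higher number a weaker inhibitor:
compound 1 `NCCCCCCOc1ccc2c(=O)c(-c3ccc(O)cc3)coc2c1`: >> 9000 nM, a limit of the assay
compound 2 `O=C(O)CCCCOc1ccc2c(=O)c(-c3ccc(O)cc3)coc2c1`: 5000 nM
compound 3 `CCOC(=O)CCCCOc1ccc2c(=O)c(-c3ccc(O)cc3)coc2c1`: > 9000 nM, a limit of the assay

Compound 3 stands at the limit of > 9000 nM in this assay, at which 1 of the 3 values shown sits, and gives no number in this assay. Compound 4 `C=CCCCCOc1ccc2c(=O)c(-c3ccc(O)cc3)coc2c1` differs from it as vinyl in place of ethoxycarbonyl on a saturated chain carbon, four bonds along the chain from an oxygen on an aromatic ring. For the measured compounds named here, no measured step touches the ethoxycarbonyl group in this way. The steps at the same chain position, an at least 1.8-fold lower number from compound 1 to compound 2 (0.25 log units; that floor lies within the scatter) and an at least 1.8-fold higher number from compound 2 to compound 3 (0.25 log units; that floor lies within the scatter), are small and bounded by limits, and a step that the two limits leave unreadable from compound 1 to compound 3. With every measured value sitting at or near a limit, only a small step is expected for compound 4, an at least 1.1-fold lower number from compound 3 to compound 4 (0.05 log units; that floor lies within the scatter), and a further limit from this assay is likely. Compound 4 is estimated at 8000 nM, within 3000 nM to 20000 nM.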

Compound 4, half-maximal inhibitory concentration: 5000 nM
Beside the measured number, compound 4's estimate is 1.6-fold (0.20 log units) above it, within the range that was stated.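

Vinyl in place of ethoxycarbonyl gives an at least 1.8-fold lower number from compound 3 to compound 4 (0.25 log units; that floor lies within the scatter) in this assay and replaces a limit with a readable number. Vinyl in place of 2-aminoethyl gives an at least 1.8-fold lower number from compound 1 to compound 4 (0.25 log units; that floor lies within the scatter) and does the same, though both floors remain small. Vinyl in place of carboxy gives no change at the digits printed from compound 2 to compound 4 (within the scatter) and so shows that a readable number at this chain position does not require the carboxy group.

Still open, on these data alone, is whether a hydroxyl or an amide at the chain end, or a shorter or longer chain, would move the value beyond the scatter.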